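The source may hold more compounds than are shown below. What is called first, only, known or untested is meant among the compounds shown, and "the series" means these compounds.

Measured in a functional assay on MCF7 cells (Homo sapiens) for antiproliferative activity, read by MTT assay; on this read-out higher numbers stand for weaker inhibition and lower numbers for stronger inhibition:
- compound 1 `CC/C=C\C/C=C\C/C=C\CCCCCCCC1(O)CC(=O)c2c(O)cc(OCOC)cc2O1`: 17500 nM
- compound 2 `CCCC/C=C\CCCCCCCCCC1(O)CC(=O)c2c(O)cc(OCOC)cc2O1`: 43200 nM
- compound 3 `CCCCC/C=C\C/C=C\CCCCCCCC1(O)CC(=O)c2c(O)cc(OCOC)cc2O1`: > 84100 nM

Compound 3 stands at > 84100 nM, which is a limit of the assay and not a number.

Compound 4 `CCCCCCCCCCCCCCCC1(O)CC(=O)c2c(O)cc(OCOC)cc2O1` has octyl in place of deca-1,4-dien-1-yl on a saturated chain carbon, seven bonds along the chain from a saturated ring carbon.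

Three measured steps alter this same chain: a 2.5-fold higher number from compound 1 to compound 2 (0.39 log units; beyond the scatter), an at least 4.8-fold higher number from compound 1 to compound 3 (0.68 log units; beyond the scatter) and an at least 1.9-fold higher number from compound 2 to compound 3 (0.28 log units; that floor lies within the scatter), the last with a floor that lies within the scatter. None of them leads to a chain without double bonds, so they guide the size only loosely.

Compound 2, at 43200 nM, gives the nearest measured number, so compound 4 is expected to remain weak in this assay. The expected change is an at least 1.2-fold lower number from compound 3 to compound 4 (0.07 log units; that floor lies within the scatter), and no clear step beyond the scatter is expected. For compound 4 the estimate is 70000 nM, with an expected range from 30000 nM to 150000 nM.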

Compound 4, half-maximal inhibitory concentration: > 67200 nM
Compound 4 ended at the assay's limit (the forecaster's own chance of this, stated with the estimate: 45%); the middle value lies beyond the limit too.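

In this assay compound 4 stands at > 67200 nM, which is a limit of the assay and not a number. Within the data shown here, a chain with no double bonds is now seen for the first time, and it gives an at least 3.8-fold higher number from compound 1 to compound 4 (0.58 log units; beyond the scatter), a step beyond the scatter, while an at least 1.5-fold higher number from compound 2 to compound 4 (0.19 log units; that floor lies within the scatter) has a floor within the scatter. The step between compound 3 and compound 4 cannot be read, since both values are limits.

The compounds shown leave open whether a longer chain, or an amine or carboxylic acid on this chain, would give stronger inhibition. As far as these compounds go, how compound 3 and compound 4 truly rank also stays unknown.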